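The source may report more compounds than this note shows. Statements on the series, on what has been measured and on what is new or still open speak of the compounds shown alone.

Working notes on the series. Two compounds have numbers in a functional assay for antagonist activity at Adrenergic receptor alpha-1 (Rattus norvegicus); a higher number here means weaker binding, a lower number tighter binding. Compound 1 `COc1cccc(OC)c1OCCNC[C@H]1Oc2ccccc2O[C@H]1C(C)C` gives 1150 nM in this assay. Compound 2 `COc1cccc(OC)c1OCCNC[C@H]1Oc2ccccc2O[C@@H]1C(C)C` shares every atom and bond with compound 1 and differs only in the configuration drawn at one saturated ring carbon. In this assay compound 2 gives 269 nM. For the measured compounds named here, the step of a 4.3-fold lower number from compound 1 to compound 2 (0.63 log units; beyond the scatter) is the only measured step so far, and compound 2 stands at the lower of the two numbers. Going by the values given here, the one piece of evidence behind that step is the fact that compounds 1 and 2 differ only in the configuration as drawn.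

Compound 3 `COc1cccc(OC)c1OCCNC[C@H]1Oc2ccccc2O[C@@H]1C1CCCCC1` keeps the configuration of compound 2 and changes one group: cyclohexyl in place of isopropyl on a saturated ring carbon. Among the compounds with values here, no measured step alters a carbon substituent, so the single step from compound 1 to compound 2 does not speak to this change directly; it shows only that this assay resolves moderate differences at the saturated ring carbon in question. For compound 3 the expectation is therefore set close to compound 2 with a wide margin, as a step of a 1.5-fold higher number from compound 2 to compound 3 (0.17 log units; within the scatter) in this assay. Compound 3 is estimated at 400 nM, within a range from 100 nM to 1600 nM.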

Compound 3, dissociation constant: 813 nM
Compound 3: the middle estimate sits 2.0-fold (0.31 log units) below what was measured, and the stated range covers the measured number.
By their numbers in this assay, from the lowest: compound 2; then compounds 3 and 1 (each within the scatter of the next).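

For the compounds shown here, this is the only measured step that alters a carbon substituent on a saturated ring carbon. In this assay, cyclohexyl in place of isopropyl gives a 3.0-fold higher number from compound 2 to compound 3 (0.48 log units; beyond the scatter) and the configuration of compound 2 is kept, so the number at this position depends on the group it carries as well as on the configuration drawn. Of these two groups, the one with 6 heavy atoms and a six-membered ring of carbon only has the higher number, while isopropyl, with 3 heavy atoms and no ring, has the lower one; the evidence in hand concerns configuration alone, and nothing in it bears on this change of group.

With a single pair, the compounds shown leave open whether the number follows the size of the group at all, since a methyl, a tert-butyl or a phenyl group at this carbon would each test that reading. Also open, on these data alone, is whether cyclohexyl in place of isopropyl gives a step of similar size in the configuration of compound 1.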